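The compounds below may be only part of what the source reports. "The series", "measured", "known", "first", "only" and "open" are said of these compounds alone.

Measured so far in this series:
- compound 1 `O=C1NC(O)(CCn2cc(C3=CCCCC3)nn2)C(OCc2ccccc2)=C1OCc1ccccc1`: in a functional assay on U-937 cells (Homo sapiens) for antiproliferative activity, read by MTT assay, with a stated time of 24 h (a lower number here means a stronger inhibitor, a higher number a weaker inhibitor), compound 1 gives > 100000 nM, which is a limit of the assay.
- compound 2 `CC(C)(C)c1ccc(-c2cn(CCC3(O)NC(=O)C(OCc4ccccc4)=C3OCc3ccccc3)nn2)cc1`: compound 2 gives 56500 nM.
- compound 3 `COC1=C(OC)C(O)(CCn2cc(-c3ccc(C(C)(C)C)cc3)nn2)NC1=O`: compound 3 gives > 100000 nM, again a limit of the assay.

Going by the values given here, compound 2 therefore holds the only actual number in this assay; the other two compounds sit at the limit of > 100000 nM in this assay, at which 2 of the 3 values shown sit. Among the compounds with values here, the one measured step, an at least 1.7-fold lower number from compound 1 to compound 2 (0.24 log units; that floor lies within the scatter), is known only as a floor because the limit of > 100000 nM in this assay, at which 2 of the 3 values shown sit, caps what compound 1 could show. Compound 3, with methoxy groups on the shared core in place of the benzyloxy groups of compound 2, returns only a limit.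

Compound 4 `Cc1ccc(-c2cn(CCC3(O)NC(=O)C(OCc4ccccc4)=C3OCc3ccccc3)nn2)cc1` differs from compound 2 by methyl in place of tert-butyl on an aromatic carbon. Within the data shown here, no measured step changes a substituent on that phenyl ring alone; the step from compound 1 to compound 2 exchanged the whole ring-bearing group and is itself only a floor within the scatter. There is thus nothing in the data to support a step beyond the scatter in either direction. The expected step of a 1.4-fold higher number from compound 2 to compound 4 (0.15 log units; within the scatter) in this assay is therefore small, with a real chance that compound 4 reaches the limit. Compound 4 is estimated at 80000 nM, within the range 30000 nM to 200000 nM.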

Compound 4, half-maximal inhibitory concentration: 54000 nM
Compound 4: the middle estimate sits 1.5-fold (0.17 log units) above what was measured; the measured number falls inside the stated range.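

In this assay, going by these compounds alone, methyl in place of tert-butyl on the aromatic carbon para to a large group gives a 1.0-fold lower number from compound 2 to compound 4 (0.02 log units; within the scatter), the first step with an actual number at both ends. Compound 2 and compound 4 cannot be told apart here, so for these two compounds, going from four heavy atoms to one at this position leaves the micromolar-range reading where it was, and the size of the tert-butyl group is not what sets the reading of compound 2. The second new step, an at least 1.8-fold lower number from compound 1 to compound 4 (0.26 log units; that floor lies within the scatter), repeats the earlier picture for the exchange of the cyclohex-1-en-1-yl group and can be read only as a floor, because one end of it is a limit rather than a number: the limit of > 100000 nM in this assay, at which 2 of the 4 values shown sit.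

Within the data shown here, only two alkyl groups stand at this position, so it remains open whether an amine, a carboxylic acid or a methoxy group in their place would give a step beyond the scatter. Going by these compounds, whether a phenyl-bearing group truly reads differently from the cyclohex-1-en-1-yl group also stays open, since both floors lie within the scatter.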